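Aryl variation on the carbon double-bonded to nitrogen

A few compounds are considered here, and "the series" means these few. Any claim that something is new, unique, unknown or untested is made for them only; others in the source may bear on it.

The series shares the core of compound 1 `CCOC(=O)c1c(N)sc(/N=C/c2ccncc2)c1C(=O)OCC` and varies only the aryl group on a carbon with a double bond to nitrogen. In a functional assay on HeLa cells (Homo sapiens) for inhibition, read by MTT assay, with a stated time of 48 h (on this read-out higher numbers stand for weaker inhibition and lower numbers for stronger inhibition), compound 1 gives 35400 nM. Among the compounds with values here, compound 2 `CCOC(=O)c1c(N)sc(/N=C/c2ccco2)c1C(=O)OCC` gives 46700 nM in this assay; among the two numbers so far compound 2 is not separated from compound 1, since a 1.3-fold higher number from compound 1 to compound 2 (0.12 log units; within the scatter). Compound 3 `CCOC(=O)c1c(N)sc(/N=C/c2ccc(C)cc2)c1C(=O)OCC` is not yet measured; it differs from compound 2 as follows: 4-methylphenyl in place of furan-2-yl on a carbon with a double bond to nitrogen. Within the data shown here, the only measured step bearing on this change is the one from compound 1 to compound 2, also an aryl-for-aryl exchange at the same place, and that step stayed within the scatter. No step beyond the scatter is therefore expected in this assay for compound 3, in either direction. For compound 3 the expected value in this assay is 40000 nM, with a range of 15000 nM to 110000 nM, which means an expected 1.2-fold lower number from compound 2 to compound 3 (0.07 log units; within the scatter).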

Compound 3, half-maximal inhibitory concentration: 41900 nM
Beside the measured number, compound 3's estimate is 1.0-fold (0.02 log units) below it; low and high end bracket the measured number.
By their numbers in this assay, from the lowest: compounds 1, 3 and 2 (each within the scatter of the next).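

In this assay, 4-methylphenyl in place of furan-2-yl on a carbon with a double bond to nitrogen gives a 1.1-fold lower number from compound 2 to compound 3 (0.05 log units; within the scatter), and 4-methylphenyl in place of pyridin-4-yl gives a 1.2-fold higher number from compound 1 to compound 3 (0.07 log units; within the scatter). A six-membered aromatic ring of carbon only thus reads like the two aryl groups with hetero atoms, and the hydrogen-bond acceptor counted in furan-2-yl is lost from compound 2 to compound 3 with no step beyond the scatter. Nothing available explains this flat result.

As far as these compounds go, whether any group at this place can move the number beyond the scatter remains open, since all three aryl groups read alike. Also open, from the compounds shown here alone, is what an aryl ring carrying an amine or a carboxylic acid, or a longer chain in place of the aryl group, would give here.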